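Swapping a Small Ring for a Larger One on the Core

The compounds below may be only part of what the source reports. "The series", "measured", "known", "first", "only" and "open" are said of these compounds alone.

Measured so far:
- Compound 1, `NC(N)=NC(=O)c1nc(Cl)c(NCc2ccccc2Cl)nc1N`: 31%
- Compound 2, `NC(N)=NC(=O)c1nc(Cl)c(NCc2ccc(Cl)cc2)nc1N`: 46%
- Compound 3, `NC(N)=NC(=O)c1nc(Cl)c(NC2CC2)nc1N`: "not determined" (no result reported)

All three share one core, and they differ only in the group attached to a nitrogen on that core. In an assay for inhibition of acid-sensing ion channel 3 (Homo sapiens), read by patch clamp, tested at 1 uM (a higher number here means more inhibition at the concentration tested (going by the name of the read-out), a lower number less inhibition), compound 1 gives 31%, and compound 2 gives 46%. For the measured compounds named here, the one step between measured compounds, a number 15 percentage points higher from compound 1 to compound 2 (beyond the scatter), is the only guide to how changes at this position move the read-out. For compound 3 no number is available in this assay, so it offers no anchor of its own.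

Compound 4, `NC(N)=NC(=O)c1nc(Cl)c(NCC2CCCCC2)nc1N`, is the next compound to be tested. Compared with compound 3 it differs as follows: cyclohexylmethyl in place of cyclopropyl on a nitrogen on an aromatic ring. Going by the values given here, no measured step covers a change of this kind, since the step from compound 1 to compound 2 alters a substituent on a ring that sits one carbon away from the nitrogen rather than replacing the whole group. Because compound 1 gives 31% and compound 2 gives 46%, both carrying groups of a shape comparable to cyclohexylmethyl, compound 4 is expected to land in the same general region, with wide uncertainty. The estimate for compound 4 in this assay is 38%, within a range from 12% to 64%.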

Compound 4, a percentage reported as inhibition, at one concentration (the size of the read-out at that concentration, not a potency): 28%
Compound 4: the middle estimate sits 10 percentage points above what was measured; the range from low to high includes it.
By their numbers in this assay, from the lowest: compounds 4 and 1 (each within the scatter of the next); then compound 2.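

In this assay, the change to cyclohexyl on the saturated chain carbon gives two different answers depending on the comparison: it brings a number 18 percentage points lower from compound 2 to compound 4 (beyond the scatter), but a number 3 percentage points lower from compound 1 to compound 4 (within the scatter). An aromatic ring on this chain carbon is therefore not needed to reach the level of compound 1, and among the three compounds with a number, only compound 2, with its 4-chlorophenyl, stands apart from the others. Nothing available explains why the 4-chlorophenyl group differs from the cyclohexyl group here, or why the two chlorophenyl groups differ from each other.

From the compounds shown here alone, compound 3 has no number, so the change from cyclopropyl to cyclohexylmethyl itself cannot be read, and the effect of ring size on the nitrogen remains unknown. Also open, going by these compounds, is how a plain phenyl without chlorine would compare on the same chain carbon, which would help separate the effect of the ring from that of the chlorine, and how a longer chain or a group carrying an amine or a carboxylic acid would read at this position.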